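Swapping a Methylamino Group for Hydroxycarbamoyl

The source may report more compounds than this note shows. Statements on the series, on what has been measured and on what is new or still open speak of the compounds shown alone.

Of the compounds shown here, two have been measured in an assay on IM-9 cells for displacement of a labelled ligand from Substance-P receptor (Homo sapiens), read by scintillation counting, with a stated time of 30 min; a lower number here means a stronger inhibitor, a higher number a weaker inhibitor. Compound 1 `CC(=O)N1CCC(C(=O)N2CC[C@H](C(=O)N(C)Cc3cc(C(F)(F)F)cc(C(F)(F)F)c3)[C@@H](c3ccccc3C(C)C)C2)CC1` gives in this assay 0.21 nM. Compound 2 `CNC(=O)N1CC[C@H](C(=O)N(C)Cc2cc(C(F)(F)F)cc(C(F)(F)F)c2)[C@@H](c2ccc(F)cc2C)C1` gives in this assay 0.048 nM, the lower of the two numbers and so the stronger inhibitor, and the gap to compound 1 lies beyond the scatter of repeated measurements. Compound 1 and compound 2 differ in several places at once, so no single structural step can be read from that gap.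

Compound 3 `Cc1cc(F)ccc1[C@H]1CN(C(=O)C(=O)NO)CC[C@@H]1C(=O)N(C)Cc1cc(C(F)(F)F)cc(C(F)(F)F)c1` differs from compound 2 in one place: hydroxycarbamoyl in place of methylamino on a carbonyl carbon. The change sits on a carbonyl carbon whose other neighbour is an amide-type nitrogen in a ring. Among the compounds with values here, no measured pair shows what this kind of change does, so the expectation rests on compound 2 alone and carries real uncertainty. The expected step is a 2.5-fold higher number from compound 2 to compound 3 (0.40 log units; beyond the scatter), a shift expected to stay small, within the scatter or only a little beyond it. Compound 3 is therefore expected to give about 0.12 nM, most likely between 0.03 nM and 0.5 nM.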

Compound 3, half-maximal inhibitory concentration: 0.046 nM
The estimate for compound 3 lay 2.6-fold (0.42 log units) above the measured number; the range from low to high includes it.
By their numbers in this assay, from the lowest: compounds 3 and 2 (each within the scatter of the next); then compound 1.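

On the carbonyl carbon whose other neighbour is the amide-type nitrogen in a ring, methylamino can give way to hydroxycarbamoyl with a 1.0-fold lower number from compound 2 to compound 3 (0.02 log units; within the scatter) in this assay, so the swap leaves no readable mark on the number. Within the data shown here, this is the first direct look at this position, and it shows that the position accepts a group with more heavy atoms, and with more hydrogen-bond donors and acceptors, without a measurable loss in this binding test. The data shown offer no explanation for why the number holds steady.

This conclusion rests on a single pair of compounds on one shared core, so it remains unclear whether the same swap would behave alike with other groups elsewhere on that core. As far as these compounds go, it also remains open how far this tolerance extends, for example whether a carboxylic acid, a simple amine or a longer alkyl chain on the same carbonyl carbon would keep the number in the same range or move it beyond the scatter.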